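The source may report more compounds than this note shows. Statements on the series, on what has been measured and on what is new or still open speak of the compounds shown alone.

Measured compounds:
compound 1 `O=c1cc(-c2ccccc2)oc2ccc(N3COc4c(Br)cc(Br)cc4C3)cc12` with 34.5%
compound 2 `O=c1cc(-c2ccccc2)oc2cc(N3COc4c(Cl)cc(Cl)cc4C3)ccc12` with 68.8%
compound 3 `O=c1cc(-c2ccccc2)oc2cc(N3COc4c(Br)cccc4C3)ccc12` with 19.5%

In a functional assay on MCF7 cells (Homo sapiens) for inhibition, read by MTT assay, with a stated time of 48 h, tested at 60 ug/mL (on this read-out lower numbers stand for less inhibition of growth and higher numbers for more inhibition of growth at the one concentration tested), compound 1 gives 34.5%, the second highest of the three numbers. The nearest value belongs to compound 3, which in this assay gives 19.5%, a number lower by more than the usual scatter. The furthest is compound 2, which in this assay gives 68.8%, a number higher by well beyond the scatter. For the measured compounds named here, compound 3 and compound 2 differ from compound 1 in more than one place, so no single step between measured compounds is available, and the three values can only be read side by side.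

The next compound is compound 4 `O=c1cc(-c2ccccc2)oc2ccc(N3COc4c(Br)cccc4C3)cc12`. It differs from compound 1 by hydrogen in place of bromo on an aromatic carbon, placed meta to a bromo group, meta to a fused ring and para to a fused ring. Going by the values given here, no measured pair shows the effect of this change on its own. The two single-halogen compounds among the measured ones, compound 3 and compound 1, both sit well below compound 2, and compound 3 carries one bromo only.

Compound 4 is therefore expected to give 25% in this assay, within 8% to 45%, an estimated step of a number 9.5 percentage points lower from compound 1 to compound 4 (within the scatter), a modest fall that may not exceed the scatter.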

Compound 4, percent growth inhibition at one concentration: 81.8%
Compound 4: the middle estimate sits 56.8 percentage points below what was measured; measured number outside the range, above it.
By their numbers in this assay, from the lowest: compound 3; then compound 1; then compound 2; then compound 4.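

In this assay, for the compounds shown here, hydrogen in place of bromo on this aromatic carbon, meta to a bromo group, meta to a fused ring and para to a fused ring, gives a number 47.3 percentage points higher from compound 1 to compound 4 (beyond the scatter) and provides the first comparison that isolates a single change. It shows that this position is far from indifferent to the substituent it carries, and that within this pair the bromo at this carbon is not needed for growth inhibition at the one concentration tested, since the compound that keeps only the other bromo stands clearly higher. Nothing available explains why the removal of one bromo has so large an effect.

What the compounds shown leave open is whether the rise belongs to hydrogen alone or whether a fluoro, a methoxy group, an amine or a carboxylic acid on the same carbon would also give a high number. They also leave open whether hydrogen in place of the remaining bromo would move the number in the same direction, or whether the same change would give a similar step on other members of the series.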